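Swapping Fluoro and Methyl on the Pyridyl Ether

The compounds below may be only part of what the source reports. "The series", "measured", "known", "first", "only" and "open" are said of these compounds alone.

Compound 1, `Cn1c(COc2cccc(C(=O)O)c2)nc2ccc(Oc3ncccc3Cl)cc21`: 1.1
Compound 2, `Cc1cnc(Oc2ccc3nc(COc4cccc(C(=O)O)c4)n(C)c3c2)c(F)c1`: 1.1

In a physicochemical assay for lipophilicity, read by LC-MS, in phosphate buffer, measured as octanol-water partition, with a stated time of 30 min, at pH 7.4, tested at 200 mM (on this read-out lower numbers stand for lower lipophilicity and higher numbers for higher lipophilicity), compound 1 gives 1.1. Compound 2 gives 1.1 in this assay and so stands level with compound 1. Among the compounds with values here, the one measured step, no change at the digits printed from compound 1 to compound 2 (within the scatter), replaced a 3-chloropyridin-2-yl with a 3-fluoro-5-methylpyridin-2-yl on an oxygen on an aromatic ring and left the read-out where it was. Compound 3, `Cc1cc(F)cnc1Oc1ccc2nc(COc3cccc(C(=O)O)c3)n(C)c2c1`, is not yet measured; it differs from compound 2 by 5-fluoro-3-methylpyridin-2-yl in place of 3-fluoro-5-methylpyridin-2-yl on an oxygen on an aromatic ring, the two having the same atoms joined differently. Since a change of whole substituents from compound 1 to compound 2 did not move the number, and the step to compound 3 merely rearranges the same fluorine and methyl on the same ring, no shift beyond the scatter is expected, no change at the digits printed from compound 2 to compound 3 (within the scatter). Compound 3 is therefore expected to give 1.1, with a range from 0.8 to 1.4.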

Compound 3, distribution coefficient: 1.1
Estimate against measurement, compound 3: no gap at the digits printed; measured number inside the range.
By their numbers in this assay, from the lowest: compounds 1, 2 and 3 (each within the scatter of the next).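

With 5-fluoro-3-methylpyridin-2-yl in place of 3-fluoro-5-methylpyridin-2-yl on an oxygen on an aromatic ring, this assay gives no change at the digits printed from compound 2 to compound 3 (within the scatter), which shows that the same atoms joined differently on this ring read alike, something the earlier pair, which differed in whole substituents, could not show. Set against 3-chloropyridin-2-yl, the new group gives no change at the digits printed from compound 1 to compound 3 (within the scatter), so all three pyridin-2-yl groups shown at this position now lie within the scatter of one another. Nothing available explains why these groups read alike.

The compounds shown leave open whether this assay would hold level with an amine or a longer alkyl chain on the pyridine ring. They also leave open whether a phenyl ring on this oxygen would read the same.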